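A few compounds are considered here, and "the series" means these few. Any claim that something is new, unique, unknown or untested is made for them only; others in the source may bear on it.

In an ADME assay on HUVEC cells (Homo sapiens) for inhibition, read by CCK-8 assay, with a stated time of 24 h, in the presence of a further agent that is not named here (a higher number here means a weaker inhibitor, a lower number a stronger inhibitor), compound 1 `Cc1cccc(-n2cc(-c3ccc(/C=C4\C(=O)Nc5ccc(F)cc54)cc3)nn2)c1` gives 9880 nM and compound 2 `O=C1Nc2ccc(F)cc2/C1=C/c1ccc(-c2cn(-c3ccccc3F)nn2)cc1` gives 14400 nM. These two values do not separate, as a 1.5-fold higher number from compound 1 to compound 2 (0.16 log units; within the scatter) lies within the scatter. Compound 3 `O=C1Nc2ccc(F)cc2/C1=C/c1ccc(-c2cn(-c3ccc(F)cc3)nn2)cc1` gives no number, only a limit of the assay: > 20000 nM. Its steps are therefore floors, an at least 2.0-fold higher number from compound 1 to compound 3 (0.30 log units; that floor lies within the scatter) and an at least 1.3-fold higher number from compound 2 to compound 3 (0.14 log units; that floor lies within the scatter), and both floors lie within the scatter.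

Compound 4 `N#Cc1cccc(-n2cc(-c3ccc(/C=C4\C(=O)Nc5ccc(F)cc54)cc3)nn2)c1` has 3-cyanophenyl in place of 4-fluorophenyl on an aromatic nitrogen. Going by the values given here, no measured step covers 3-cyanophenyl itself. The three exchanges at this nitrogen are the only guide, and none is shown to go beyond the scatter. A step beyond the scatter is therefore not expected, although the start from a limit leaves its true size open. The expected direction is a lower number, if any, into the range held by compound 1 at 9880 nM. The estimated step is an at least 1.4-fold lower number from compound 3 to compound 4 (0.15 log units; that floor lies within the scatter). For compound 4 the expected value in this assay is 14000 nM, with an estimated range of 7000 nM to 20000 nM.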

Compound 4, half-maximal inhibitory concentration: > 20000 nM
Compound 4 gave a limit, no number; the forecaster's own chance of this, stated with the estimate: 25%; middle value at least 1.4-fold (0.15 log units) away from the limit.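

At this nitrogen, 3-cyanophenyl joins 4-fluorophenyl at the limit in this assay, and the step between compound 3 and compound 4 cannot be read. The two compounds with numbers give only floors, an at least 2.0-fold higher number from compound 1 to compound 4 (0.30 log units; that floor lies within the scatter) and an at least 1.3-fold higher number from compound 2 to compound 4 (0.14 log units; that floor lies within the scatter), so cyano in place of methyl on an aromatic carbon is not shown to move the value beyond the scatter. The reading for compound 4 is a limit, not a number, so the hydrogen-bond acceptor of 3-cyanophenyl adds a second compound at that limit: the limit of > 20000 nM in this assay, at which 2 of the 4 values shown sit.

From the compounds shown here alone, it remains open whether an amine or a carboxylic acid on the phenyl ring, or a longer chain on this nitrogen, would separate clearly from compound 1. Going by these compounds, the true distance of compound 3 and compound 4 from the compounds with numbers also remains open.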